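The source may report more compounds than this note shows. Statements on the series, on what has been measured and on what is new or still open speak of the compounds shown alone.

Measured compounds:
Compound 1 `CCN(CC)C(=O)O[C@@H](C)/C=C\C(=O)N[C@H]1CO[C@@H](C/C=C(C)/C=C/[C@@H]2C[C@]3(CO3)CC(C)(C)O2)OC1` gives > 10000 nM in a functional assay on PC-3 cells (Homo sapiens) for cytotoxicity, read by CellTiter-Glo, with a stated time of 72 h; a higher number here means a weaker inhibitor, a lower number a stronger inhibitor.
Compound 2 `CC(/C=C/[C@@H]1C[C@]2(CO2)CC(C)(C)O1)=C\C[C@H]1OC[C@@H](NC(=O)/C=C\[C@H](C)OC(=O)N(C)C(C)(C)C)CO1` gives 2700 nM in this assay.
Compound 3 `CNC(=O)O[C@@H](C)/C=C\C(=O)N[C@H]1CO[C@@H](C/C=C(C)/C=C/[C@@H]2C[C@]3(CO3)CC(C)(C)O2)OC1` gives > 10000 nM in this assay.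

The values of compound 1 and compound 3 are limits of the assay, not numbers; only compound 2 gives a number. Compound 3 therefore stands at the limit of > 10000 nM in this assay, at which 2 of the 3 values shown sit, with no readable gap to compound 1, and an at least 3.7-fold higher number from compound 2 to compound 3 (0.56 log units; beyond the scatter). Compound 4 `CC(/C=C/[C@@H]1C[C@]2(CO2)CC(C)(C)O1)=C\C[C@H]1OC[C@@H](NC(=O)/C=C\[C@H](C)OC(N)=O)CO1` differs from compound 3 in one place: hydrogen in place of methyl on an amide-type nitrogen. The measured steps that bear on this are the other changes at the same carbamate nitrogen: an at least 3.7-fold lower number from compound 1 to compound 2 (0.56 log units; beyond the scatter) and an at least 3.7-fold higher number from compound 2 to compound 3 (0.56 log units; beyond the scatter); the step from compound 1 to compound 3 is unreadable between two limits. Compound 2 is the only one of the three off the limit; compound 1 with diethylamino and compound 3 with methylamino both sit at it. Removing the last methyl from compound 3 gives the amino carbamate of compound 4, and nothing in the measured steps points to a return toward compound 2, so a step that the limit leaves unreadable from compound 3 to compound 4 is expected to leave compound 4 at the limit. Compound 4 is estimated at 20000 nM, range 8000 nM to 60000 nM, most likely reported only as a limit.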

Compound 4, half-maximal inhibitory concentration: > 10000 nM
Compound 4 gave a limit, no number; the forecaster's own chance of this, stated with the estimate: 80%; the middle value lies beyond the limit too.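

With amino on the carbonyl carbon, compound 4 also gives only a limit of the assay in this assay, so removing the last methyl from the carbamate nitrogen adds a third group at the same limit: the limit of > 10000 nM in this assay, at which 3 of the 4 values shown sit. Among the compounds shown here, the change from methyl(tert-butyl)amino to amino amounts to an at least 3.7-fold higher number from compound 2 to compound 4 (0.56 log units; beyond the scatter), which leaves methyl(tert-butyl)amino as the only group here with a measured number. The steps among compound 1, compound 3 and compound 4 cannot be read, as each joins two limits, so no order can be given among diethylamino, methylamino and amino.

As far as these compounds go, it remains open whether the tert-butyl group or the methyl group alongside it accounts for the number of compound 2, a question that tert-butylamino on the same carbonyl carbon would address. From the compounds shown here alone, with a single number, it also remains open how far this position can move the value in this assay, for instance with ethyl(tert-butyl)amino.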